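The source may report more compounds than this note shows. Statements on the series, on what has been measured and on what is new or still open speak of the compounds shown alone.

In a functional assay on cells (Platelet, Homo sapiens) for inhibition (a lower number here means a stronger inhibitor, a higher number a weaker inhibitor), compound 1 `CCOC(=O)c1ccc(-c2nn(Cc3ccc(OC)cc3)c3ccccc23)cc1` gives 620 nM. Compound 2 `CC(C)OC(=O)c1ccc(-c2nn(Cc3ccccc3)c3ccccc23)cc1` gives > 10000 nM, which is a limit of the assay and not a number. The standing of compound 2 is therefore (the limit of > 10000 nM in this assay, at which 1 of the 2 values shown sits).

The next structure, compound 3 `OCc1ccc(-c2nn(Cc3ccccc3)c3ccccc23)cc1`, differs from compound 2 in one place, on an aromatic carbon of a six-membered aromatic ring of carbon only, para to a large group. The change is hydroxymethyl in place of isopropoxycarbonyl on an aromatic carbon.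

Among the compounds with values here, no measured pair in this small set isolates that change, so its size cannot be read from the data, and any forecast is loose. In this assay, within the data shown here, a moderate move toward stronger inhibition is expected, resting on compound 1 at 620 nM as the only sign that a compound of this kind can register a number. Another limit remains a real possibility. The expected change is an at least 3.3-fold lower number from compound 2 to compound 3 (0.52 log units; beyond the scatter). For compound 3 the estimate is 3000 nM, with an expected range from 700 nM to 10000 nM.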

Compound 3, half-maximal inhibitory concentration: > 10000 nM
Compound 3 ended at the assay's limit (the forecaster's own chance of this, stated with the estimate: 30%); at least 3.3-fold (0.52 log units) between middle value and limit.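

Compound 2 and compound 3 both give a limit of the assay rather than a number, so the step between them cannot be read: the limit of > 10000 nM in this assay, at which 2 of the 3 values shown sit.

The compounds shown leave open whether hydroxymethyl in place of isopropoxycarbonyl on an aromatic carbon changes inhibition at all, and in which direction.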